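Aryl amide variation on the shared core

The source may hold more compounds than are shown below. What is called first, only, known or untested is meant among the compounds shown, and "the series" means these compounds.

Measured so far, all in a functional assay on MCF7 cells (Homo sapiens) for antiproliferative activity, read by CCK-8 assay, with a stated time of 72 h; a lower number here means a stronger inhibitor, a higher number a weaker inhibitor:
compound 1 `O=C(Nc1cccc(-c2oc3cc(-c4ccc(F)cc4)ccc3c(=O)c2O)c1)c1ccc(F)cc1F` gives 13500 nM
compound 2 `COc1cccc(C(=O)Nc2cccc(-c3oc4cc(-c5ccc(F)cc5)ccc4c(=O)c3O)c2)c1` gives 15300 nM

Compound 2 stands at the higher of the two numbers, but the step of a 1.1-fold higher number from compound 1 to compound 2 (0.05 log units; within the scatter) is within the scatter, so the two compounds cannot be ordered on these data. Compound 3 `Cc1cc(C(=O)Nc2cccc(-c3oc4cc(-c5ccc(F)cc5)ccc4c(=O)c3O)c2)ccc1F` is not yet measured; it differs from compound 2 by 4-fluoro-3-methylphenyl in place of 3-methoxyphenyl on a carbonyl carbon. Among the compounds with values here, the only measured step that bears on this change is the earlier exchange at the same carbonyl carbon, a 1.1-fold higher number from compound 1 to compound 2 (0.05 log units; within the scatter), which left the number unchanged beyond the scatter. On that basis compound 3 is expected to show no step beyond the scatter in this assay, a 1.2-fold lower number from compound 2 to compound 3 (0.07 log units; within the scatter). The estimate for compound 3 in this assay is 13000 nM, with a range from 5000 nM to 35000 nM.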

Compound 3, half-maximal inhibitory concentration: 7710 nM
Compound 3: the middle estimate sits 1.7-fold (0.23 log units) above what was measured; the range from low to high includes it.
By their numbers in this assay, from the lowest: compounds 3, 1 and 2 (each within the scatter of the next).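

With a 2.0-fold lower number from compound 2 to compound 3 (0.30 log units; within the scatter) and a 1.8-fold lower number from compound 1 to compound 3 (0.24 log units; within the scatter) in this assay the third aryl amide on the shared core also stays within the scatter of both earlier compounds. Within the data shown here, the exchange of 3-methoxyphenyl for 4-fluoro-3-methylphenyl on the carbonyl carbon goes from 1 hydrogen-bond acceptor to 0 in the group, and among compounds 1, 2 and 3 no step at this position lies beyond the scatter. No measurement shown here accounts for these numbers.

Still open, from the compounds shown here alone, is whether anything other than a substituted phenyl on this carbonyl carbon moves the number beyond the scatter, for example a piperidine amine, a benzoic acid carboxylic acid or a longer alkyl chain. Also open, going by these compounds, is whether the same flat reading holds for these amides on any other core.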